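Benzylsulfanyl swap on the shared core: compound 2 to 3

The compounds below may be only part of what the source reports. "The series", "measured", "known", "first", "only" and "open" are said of these compounds alone.

Compound 2 `Cc1cc(Nc2cc(-c3ccccc3)[nH]n2)n2nc(SCc3ccccc3Br)nc2n1` is assessed in a functional assay on MGC-803 cells (Homo sapiens) for inhibition, read by MTT assay, with a stated time of 72 h (on this read-out higher numbers stand for weaker inhibition and lower numbers for stronger inhibition), where compound 2 gives 3650 nM. Going by the values given here, the only other measured member of the series is compound 1 `Cc1cc(Nc2ccn(Cc3cccc4ccccc34)n2)n2nc(SCc3ccc(Br)cc3)nc2n1`, and in this assay compound 1 gives 3240 nM; the two numbers sit within the scatter of each other, so neither compound can be set above the other on these data. Among the compounds with values here, no step between measured compounds that differ in one place is available, so nothing measured anchors the move to compound 3 `COc1ccc(CSc2nc3nc(C)cc(Nc4cc(-c5ccccc5)[nH]n4)n3n2)cc1`. Against compound 2 the change is 4-methoxyphenyl in place of 2-bromophenyl on a saturated chain carbon bound to a sulfur. Within the data shown here, with no comparable step on record, the expected step from compound 2 to compound 3 in this assay is a 1.0-fold lower number from compound 2 to compound 3 (0.02 log units; within the scatter), that is, none beyond the scatter in either direction. Compound 3 is therefore expected to give about 3500 nM in this assay, within a range of 1400 nM to 9000 nM.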

Compound 3, half-maximal inhibitory concentration: 3170 nM
Beside the measured number, compound 3's estimate is 1.1-fold (0.04 log units) above it, and the stated range covers the measured number.
By their numbers in this assay, from the lowest: compounds 3, 1 and 2 (each within the scatter of the next).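

In this assay the series now has its first step at a single place: 4-methoxyphenyl in place of 2-bromophenyl on a saturated chain carbon bound to a sulfur gives a 1.2-fold lower number from compound 2 to compound 3 (0.06 log units; within the scatter). At this position, then, exchanging a bromine-bearing ring for one that carries a hydrogen-bond acceptor leaves the number within the scatter, though this is one pair and sets no pattern. No measurement on hand bears on the size of this step.

The step alters the substituent and its ring position in one move, so 2-bromophenyl and 4-methoxyphenyl alone cannot separate the two. Also open, going by these compounds, is whether a carboxylic acid or an amine on the phenyl ring, or a longer chain in place of the benzyl group, would move the number beyond the scatter.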